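Amine in place of the hydroxyproline acid on compound 1

This account rests on a few compounds, and the source may have more. Where it says the series, first, only, none or still open, it means among the compounds named here.

Measured so far:
compound 1, `COc1ccc(/C=C\c2cc(OC)c(OC)c(OC)c2)cc1OCc1ccc(CN2C[C@H](O)C[C@@H]2C(=O)O)cc1`: > 10000 nM
compound 2, `COc1ccc(/C=C\c2cc(OC)c(OC)c(OC)c2)cc1OCc1ccc(CN2CCCC[C@H]2C(=O)O)cc1`: > 10000 nM

In a functional assay on B16-F10 cells (Mus musculus) for antiproliferative activity, read by CCK-8 assay, with a stated time of 48 h (a higher number here means a weaker inhibitor, a lower number a stronger inhibitor), compound 1 gives only a limit, > 10000 nM. Compound 2 gives only a limit as well in this assay, > 10000 nM. Within the data shown here, the one measured step, a step that the two limits leave unreadable from compound 1 to compound 2, is therefore not readable in size or direction; both values sit at the limit of > 10000 nM in this assay, at which 2 of the 2 values shown sit. Compound 3, `COc1ccc(/C=C\c2cc(OC)c(OC)c(OC)c2)cc1OCc1ccc(CNCCO)cc1`, has not been measured in this assay. The change from compound 1 is (2-hydroxyethyl)amino in place of 2-carboxy-4-hydroxypyrrolidin-1-yl on a saturated chain carbon bound to an aromatic carbon. Among the measured compounds shown here, the measured step kept a carboxylic acid on the ring and exchanged one ring for another, so no measured step bears on the removal of the acid and the ring together. The step of an at least 1.4-fold lower number from compound 1 to compound 3 (0.15 log units; that floor lies within the scatter) is expected to be small, and may well not be readable, since compound 1 stands at a limit. Compound 3 is expected to give about 7000 nM, within 1200 nM to 40000 nM, with a real chance that only a limit is reported again.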

Compound 3, half-maximal inhibitory concentration: 6600 nM
Compound 3: middle estimate off by 1.1-fold (0.03 log units), on the high side; the range from low to high includes it.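

In this assay, among these compounds, compound 3 gives 6600 nM as the only value shown that is not a limit, with (2-hydroxyethyl)amino on a saturated chain carbon bound to an aromatic carbon. Among the compounds shown here, with an at least 1.5-fold lower number from compound 1 to compound 3 (0.18 log units; that floor lies within the scatter) and an at least 1.5-fold lower number from compound 2 to compound 3 (0.18 log units; that floor lies within the scatter) as the only readings, the change has a floor inside the scatter and its true size stays unknown. The two compounds that keep a ring and a carboxylic acid, compound 1 and compound 2, stay at a limit: the limit of > 10000 nM in this assay, at which 2 of the 3 values shown sit.

The ring and the carboxylic acid leave together in this change, so the two are not separated. Open, going by these compounds, are a ring amine without the acid, such as piperidine, an open chain that keeps a carboxylic acid, and a plain amine or longer chain without the hydroxyl.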